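The compounds below may be only part of what the source reports. "The series", "measured", "known", "first", "only" and "open" are said of these compounds alone.

Within the data shown here, compound 2 `O=C(C1=C(OC2CCCCC2)C(=O)N(CCCn2ccnc2)C1c1ccc(Br)cc1)c1ccccc1` gives 31200 nM in a functional assay on A549 cells (Homo sapiens) for antiproliferative activity, read by MTT assay, with a stated time of 72 h (a lower number here means a stronger inhibitor, a higher number a weaker inhibitor), and stands second highest of the three numbers so far, though compound 1 `CCOC1=C(C(=O)c2ccccc2)C(c2ccc(Br)cc2)N(CCCn2ccnc2)C1=O` at 35300 nM and compound 3 `O=C(C1=C(Nc2ccc(F)cc2)C(=O)N(CCCn2ccnc2)C1c1ccc(Br)cc1)c1ccccc1` at 27400 nM both lie within the scatter of it. Compound 4 `O=C(C1=C(Nc2ccc(Cl)cc2)C(=O)N(CCCn2ccnc2)C1c1ccc(Br)cc1)c1ccccc1` differs from compound 2 by (4-chlorophenyl)amino in place of cyclohexyloxy on a double-bonded ring carbon. The closest measured step is a 1.1-fold lower number from compound 2 to compound 3 (0.06 log units; within the scatter), which puts a (4-fluorophenyl)amino group in the same place; a 1.3-fold lower number from compound 1 to compound 3 (0.11 log units; within the scatter) points the same way, and a 1.1-fold lower number from compound 1 to compound 2 (0.05 log units; within the scatter) shows that exchanging ethoxy for cyclohexyloxy barely moves the number. None of these steps leaves the scatter, so no step beyond the scatter is expected in this assay for compound 4. Compound 4 is therefore estimated at 27000 nM (range 13000 nM to 55000 nM), an expected step of a 1.2-fold lower number from compound 2 to compound 4 (0.06 log units; within the scatter).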

Compound 4, half-maximal inhibitory concentration: 30000 nM
The estimate for compound 4 lay 1.1-fold (0.05 log units) below the measured number; low and high end bracket the measured number.
By their numbers in this assay, from the lowest: compounds 3, 4, 2 and 1 (each within the scatter of the next).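

In this assay, the position on the double-bonded ring carbon accepts (4-chlorophenyl)amino with no step beyond the scatter from either ether, with a 1.0-fold lower number from compound 2 to compound 4 (0.02 log units; within the scatter) and a 1.2-fold lower number from compound 1 to compound 4 (0.07 log units; within the scatter). Chloro in place of fluoro on the aromatic carbon also stays inside the scatter, with a 1.1-fold higher number from compound 3 to compound 4 (0.04 log units; within the scatter), so this halogen exchange adds a second change at this position that leaves the number in place. No data bearing on the reason for this are available.

From the compounds shown here alone, it remains open whether a carboxylic acid or a piperazine at this position would give a step beyond the scatter. Going by these compounds, it is also open whether a different group in place of 4-bromophenyl would alter how this position responds.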